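Lengthening an isothiocyanate chain on a new core

The source may report more compounds than this note shows. Statements on the series, on what has been measured and on what is new or still open speak of the compounds shown alone.

Measured compounds:
compound 1, `CN(C)C(=O)c1cc2cnc(Nc3ccc(S(=O)(=O)NCCCN=C=S)cc3)nc2n1C1CCCC1`, 58.9%
compound 2, `CN(C)C(=O)c1cc2cnc(Nc3ccc(S(=O)(=O)NCCCCN=C=S)cc3)nc2n1C1CCCC1`, 39.4%
compound 3, `CN(C)C(=O)c1cc2cnc(Nc3ccc(C(=O)NCCCCN=C=S)cc3F)nc2n1C1CCCC1`, -7%

Of the compounds shown here, three have been tested in a functional assay on A549 cells (Homo sapiens) for inhibition, read by CCK-8 assay, with a stated time of 72 h, tested at 1 uM; a lower number here means a weaker effect, a higher number a stronger effect of the compound at the concentration tested. Compound 1 gives 58.9%, compound 2 gives 39.4%, and compound 3 gives -7%, the lowest of the three. Compound 1 and compound 2 share a core and differ by a group of 4 heavy atoms (2 carbon, 1 nitrogen, 1 sulfur; no ring) in place of a group of 3 heavy atoms (1 carbon, 1 nitrogen, 1 sulfur; no ring), on a saturated chain carbon, three bonds along the chain from a sulfonamide nitrogen; this step was a number 19.5 percentage points lower from compound 1 to compound 2 (beyond the scatter). Compound 3 stands on a different core; how the two cores differ is not broken down here.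

Compound 4, `CN(C)C(=O)c1cc2cnc(Nc3ccc(C(=O)NCCCCCN=C=S)cc3F)nc2n1C1CCCC1`, is not yet measured. It differs from compound 3 by a group of 4 heavy atoms (2 carbon, 1 nitrogen, 1 sulfur; no ring) in place of a group of 3 heavy atoms (1 carbon, 1 nitrogen, 1 sulfur; no ring), on a saturated chain carbon, four bonds along the chain from an amide-type nitrogen. This is the same kind of change as from compound 1 to compound 2, but not the same: the place is four bonds along the chain from an amide-type nitrogen rather than three bonds from a sulfonamide nitrogen. Because the earlier step was a number 19.5 percentage points lower from compound 1 to compound 2 (beyond the scatter), and because compound 3 already gives -7%, little room for a further fall is expected, so the step is estimated at a number 2 percentage points higher from compound 3 to compound 4 (within the scatter). Compound 4 is expected to give -5%, likely between -25% and 15%.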

Compound 4, a percentage reported as inhibition, at one concentration (the size of the read-out at that concentration, not a potency): -1.6%
The estimate for compound 4 lay 3.4 percentage points below the measured number; low and high end bracket the measured number.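

Lengthening the chain that ends in the isothiocyanate does not behave the same way on the two cores in this assay: the same change on two cores in this assay, a number 19.5 percentage points lower (beyond the scatter) from compound 1 to compound 2 and a number 5.4 percentage points higher (within the scatter) from compound 3 to compound 4, 24.9 percentage points apart, beyond the scatter of two such steps

On the core of compound 3 the step is a number 5.4 percentage points higher from compound 3 to compound 4 (within the scatter), so the two compounds cannot be told apart, and the drop seen on the core of compound 1 does not carry over. Within the data shown here, this does not show which feature of the cores sets the two steps apart: the change sits three bonds from a sulfonamide nitrogen on one core and four bonds from an amide-type nitrogen on the other, and each core offers only a single pair, tested at one concentration.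

The compounds shown leave open what a still longer chain would give on either core. They also leave open what an amine or a carboxylic acid at the end of the chain, in place of the isothiocyanate, would do in this assay.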